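A few compounds are considered here, and "the series" means these few. Any claim that something is new, unique, unknown or untested is made for them only; others in the source may bear on it.

Measured compounds:
compound 1 `Cc1cccnc1-c1ccc(C(=O)Nc2ccc(C(C)(C)C)cc2)cc1` — 9 nM
compound 2 `CC(C)(C)c1ccc(NC(=O)c2ccc(-c3ncccc3C#N)cc2)cc1` — 13 nM
compound 3 `CCS(=O)(=O)Nc1cccnc1-c1ccc(C(=O)Nc2ccc(C(C)(C)C)cc2)cc1` — 4 nM

All three numbers come from a functional assay for antagonist activity at transient receptor potential cation channel subfamily V member 1 (Rattus norvegicus); a lower number here means a stronger inhibitor, a higher number a weaker inhibitor. Compound 3 holds the lowest number of the three, and both of its steps from the others lie beyond the scatter: a 2.3-fold lower number from compound 1 to compound 3 (0.35 log units; beyond the scatter) and a 3.3-fold lower number from compound 2 to compound 3 (0.51 log units; beyond the scatter). The remaining step, a 1.4-fold higher number from compound 1 to compound 2 (0.16 log units; within the scatter), is within the scatter, so compound 1 and compound 2 cannot be ordered.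

Compound 4 `CC(C)(C)c1ccc(NC(=O)c2ccc(-c3ncccc3N(S(C)(=O)=O)S(C)(=O)=O)cc2)cc1` differs from compound 3 by bis(methylsulfonyl)amino in place of (ethylsulfonyl)amino on an aromatic carbon, sitting on an aromatic carbon of a six-membered aromatic ring with 1 nitrogen, ortho to a large group, two atoms from the ring nitrogen. Among the measured compounds shown here, no measured step covers this change. The two steps onto compound 3 show that a sulfonyl-bearing group at this carbon gave modest gains over methyl and cyano, but neither speaks to removing the hydrogen-bond donor or adding a second methylsulfonyl. The expectation is a small loss, possibly within the scatter, a 2.5-fold higher number from compound 3 to compound 4 (0.40 log units; beyond the scatter). Compound 4 is therefore estimated at 10 nM, with a range from 3 nM to 40 nM.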

Compound 4, half-maximal inhibitory concentration: 0.4 nM
Estimate against measurement, compound 4: 25-fold (1.40 log units) above; the whole stated range lies above it.
By their numbers in this assay, from the lowest: compound 4; then compound 3; then compounds 1 and 2 (each within the scatter of the next).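

At this aromatic carbon, two atoms from the ring nitrogen, bis(methylsulfonyl)amino has no hydrogen-bond donor, yet in this assay it gives a 10-fold lower number from compound 3 to compound 4 (1.00 log units; beyond the scatter), so a donor on this substituent is not needed for a low number. Against the smaller groups the gain widens to a 23-fold lower number from compound 1 to compound 4 (1.35 log units; beyond the scatter) and a 33-fold lower number from compound 2 to compound 4 (1.51 log units; beyond the scatter), both larger than any step among the earlier compounds. Nothing measured in this set bears on why the number falls.

The compounds shown do not separate losing the donor from gaining a second sulfonyl, a question that a methyl(methylsulfonyl)amino group at this carbon would address. Going by these compounds, whether bis(ethylsulfonyl)amino or a plain amine here would hold a number this low remains open.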